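The source may report more compounds than this note shows. Statements on the series, on what has been measured and on what is new or still open speak of the compounds shown alone.

Working notes on the series in a physicochemical assay for solubility, with a stated time of 24 h, tested at 30 mg/mL (on this read-out higher numbers stand for higher solubility and lower numbers for lower solubility), follow. Here compound 1 `O=C(CCCCCCNc1c(Nc2ccccc2)c(=O)c1=O)NO` gives 1800000 nM as its reading. Compound 2 `O=C(CCCCCNc1c(NCc2ccccc2)c(=O)c1=O)NO` gives 5700000 nM as the higher of the two numeric readings, and its gap to compound 1 lies beyond the scatter. Compound 3 `CC(C)(Nc1c(NCCCCCC(=O)NO)c(=O)c1=O)c1ccccc1` gives only a limit, > 84000000 nM and no number. The next compound to follow is compound 4 `Cc1ccc(Nc2c(NCCCCCC(=O)NO)c(=O)c2=O)cc1` which is still unmeasured. Relative to compound 2, it carries 4-methylphenyl in place of benzyl on a nitrogen on an aromatic ring while the two keep the same atoms, joined differently. Within the data shown here, no measured step shows this change on its own, so the expectation rests on neighbouring values. Compound 1 at 1800000 nM is taken as the measured neighbour closest in shape to compound 4. A step towards a lower number is therefore expected, estimated as a 3.8-fold lower number from compound 2 to compound 4 (0.58 log units; beyond the scatter) in this assay and probably beyond the scatter. For compound 4 the estimate is 1500000 nM with an expected range from 400000 nM to 6000000 nM on this read-out.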

Compound 4, solubility: 1800000 nM
Compound 4: middle estimate off by 1.2-fold (0.08 log units), on the low side; the range from low to high includes it.
By their numbers in this assay, from the lowest: compounds 1 and 4 (each within the scatter of the next); then compound 2. At a limit, above all of these: compound 3.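

In this assay placing 4-methylphenyl in place of benzyl on a nitrogen on an aromatic ring gives a 3.2-fold lower number from compound 2 to compound 4 (0.50 log units; beyond the scatter) as a modest step. Among these compounds, the earlier compounds offered no pair differing in one place, so this is the only direct reading of a change at this position, and it lies beyond the scatter. With the atoms the same and only their joining different, the pair shows that this rearrangement alone moves the reading, though one pair gives the size and direction of the step and no cause.

Still open, from the compounds shown here alone, is whether a carboxylic acid or an amine in place of the methyl on the phenyl ring, or a longer chain on that nitrogen, would move the reading in the same direction. Compound 3 gives only a limit, so no step to it can be read: the limit of > 84000000 nM in this assay, at which 1 of the 4 values shown sits.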